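The compounds below may be only part of what the source reports. "The series", "measured", "known", "first", "only" and "open" are said of these compounds alone.

Working notes on the series.

Three members of the series have been measured in a functional assay on FL5.12 cells (Mus musculus) for cytotoxicity, read by flow cytometry, with a stated time of 48 h; a higher number here means a weaker inhibitor, a lower number a stronger inhibitor. Compound 1 `CCCCCCc1ccc(CO[C@@H]2CN[C@@H](CO)C2)cc1` gives 2700 nM, compound 2 `CCCC/C=C/c1ccc(CO[C@@H]2CN[C@@H](CO)C2)cc1` gives 5500 nM, and compound 3 `CCCCCCCCCCCCCCc1ccc(CO[C@@H]2CN[C@@H](CO)C2)cc1` gives 10500 nM. Compound 2 thus stands second highest of the three numbers: its nearest neighbour is compound 3, within the scatter, and its furthest is compound 1, beyond the scatter, as the step of a 2.0-fold higher number from compound 1 to compound 2 (0.31 log units; beyond the scatter) shows.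

Compound 4 `CCCCCCCCCCCC/C=C/c1ccc(CO[C@@H]2CN[C@@H](CO)C2)cc1` is not yet measured. Its difference from compound 2 is octyl in place of hydrogen on a saturated chain carbon, four bonds along the chain from a double-bonded chain carbon. Going by the values given here, the step that bears on it is the one from compound 1 to compound 3, which is the same change of hydrogen to octyl on a saturated chain and gave a 3.9-fold higher number from compound 1 to compound 3 (0.59 log units; beyond the scatter). Carrying that step over, a modest move to a higher number, beyond the scatter, is expected for compound 4 in this assay, namely a 3.6-fold higher number from compound 2 to compound 4 (0.56 log units; beyond the scatter). Compound 4 is therefore estimated at 20000 nM, with a range from 8000 nM to 50000 nM.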

Compound 4, half-maximal inhibitory concentration: 5100 nM
Compound 4: middle estimate off by 3.9-fold (0.59 log units), on the high side; measured number below the stated range.
By their numbers in this assay, from the lowest: compounds 1, 4, 2 and 3 (each within the scatter of the next, the first and the last beyond it).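

In this assay, octyl in place of hydrogen on a saturated chain carbon, four bonds along the chain from a double-bonded chain carbon, gives a 1.1-fold lower number from compound 2 to compound 4 (0.03 log units; within the scatter), a step within the scatter. The earlier compounds shown here showed this change only on the fully saturated chain, where it gave a 3.9-fold higher number from compound 1 to compound 3 (0.59 log units; beyond the scatter). The added octyl therefore does not carry the same step from one core to the other, and the double bond in the chain is the one difference between the two pairs: the same change on two cores in this assay, a 3.9-fold higher number (0.59 log units; beyond the scatter) from compound 1 to compound 3 and a 1.1-fold lower number (0.03 log units; within the scatter) from compound 2 to compound 4, 4.2-fold (0.62 log units) apart, beyond the scatter of two such steps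

Two pairs do not show whether this gap would also appear with a triple bond in place of the double bond. Nor do they show how an amine or a carboxylic acid in place of octyl would read on either core.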